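A few compounds are considered here, and "the series" means these few. Any claim that something is new, unique, unknown or untested is made for them only; others in the source may bear on it.

Three compounds were measured in an assay on isolated protein for agonist activity at melatonin receptor type 1C (Xenopus laevis), read by spectrophotometry; a higher number here means that more compound is needed for the effect, a lower number that less compound is needed. Compound 1, `COc1ccc(CNC(C)=O)cc1F`, gives 1510 nM in this assay. Compound 2, `CCC(=O)NCc1ccc(OC)c(F)c1`, gives 1050 nM in this assay. Compound 2 differs from compound 1 by methyl in place of hydrogen on a saturated chain carbon bound to a carbonyl carbon, and that change made a 1.4-fold lower number from compound 1 to compound 2 (0.16 log units; within the scatter). Compound 3, `CCC(=O)NCCCc1ccc(OC)c(F)c1`, gives 871 nM in this assay; how its core differs from the core of compound 1 is not broken down here.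

Compound 4, `CCCC(=O)NCCCc1ccc(OC)c(F)c1`, has not yet been measured. It differs from compound 3 by methyl in place of hydrogen on a saturated chain carbon, two bonds along the chain from a carbonyl carbon. Going by the values given here, this is the same kind of change as the one between compound 1 and compound 2, but not the same change: there the methyl entered on a saturated chain carbon bound to a carbonyl carbon, here it enters on a saturated chain carbon, two bonds along the chain from a carbonyl carbon. Because the earlier step of this kind was a 1.4-fold lower number from compound 1 to compound 2 (0.16 log units; within the scatter), a similarly small step is expected, estimated as a 1.2-fold lower number from compound 3 to compound 4 (0.09 log units; within the scatter). Compound 4 is therefore expected to give about 700 nM in this assay, with a likely range from 350 nM to 1400 nM.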

Compound 4, half-maximal effective concentration: 417 nM
The estimate for compound 4 lay 1.7-fold (0.22 log units) above the measured number, and the stated range covers the measured number.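

In this assay, methyl in place of hydrogen on a saturated chain carbon, two bonds along the chain from a carbonyl carbon, made a 2.1-fold lower number from compound 3 to compound 4 (0.32 log units; beyond the scatter). Set beside the earlier step of this kind on another core, the new step cannot be told apart from it in size: the same change on two cores in this assay, a 1.4-fold lower number (0.16 log units; within the scatter) from compound 1 to compound 2 and a 2.1-fold lower number (0.32 log units; beyond the scatter) from compound 3 to compound 4, 1.5-fold (0.16 log units) apart, within the scatter of two such steps. This is compatible with the added methyl carrying over between these two cores, but it does not establish a rule, as the methyl enters at a different place in each step, only the new step lies beyond the scatter, and just two cores are shown.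

The compounds shown leave open whether a longer chain on the carbonyl would extend this step, and whether an amine or a carboxylic acid at the end of that chain would preserve it. They also leave open how the propylcarbonyl group would read on the core of compound 1.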